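Swapping a ring amine for an open chain

This account rests on a few compounds, and the source may have more. Where it says the series, first, only, none or still open, it means among the compounds named here.

In a functional assay on L02 cells (Homo sapiens) for cytotoxicity, read by MTT assay, with stated times of 48 h and 4 h (a higher number here means a weaker inhibitor, a lower number a stronger inhibitor), compound 1 `CC(C)N(CCNc1nc(/C=C/c2ccc([N+](=O)[O-])cc2)nc2ccccc12)C(C)C` gives 8960 nM. Compound 2 `O=[N+]([O-])c1ccc(/C=C/c2nc(NCCN3CCCCC3)c3ccccc3n2)cc1` gives > 100000 nM, which is a limit of the assay and not a number. Going by these compounds, this places compound 2 at the limit of > 100000 nM in this assay, at which 1 of the 2 values shown sits, so its true position is unknown.

The next compound, compound 3 `CCN(CC)CCCNc1nc(/C=C/c2ccc([N+](=O)[O-])cc2)nc2ccccc12`, has (diethylamino)methyl in place of piperidin-1-yl on a saturated chain carbon, two bonds along the chain from a nitrogen on an aromatic ring. The ring of compound 2 is gone, and the amine of compound 3 is open-chain, as in compound 1.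

Within the data shown here, only one measured step bears on this change: an at least 11-fold higher number from compound 1 to compound 2 (1.04 log units; beyond the scatter). That large step, beyond the scatter, came with piperidin-1-yl replacing diisopropylamino. It is thin evidence, since diethylamino is a different amine on a different chain. Even so, a large step toward a lower number in this assay is expected, although another limit remains possible.

The expected step is an at least 5.0-fold lower number from compound 2 to compound 3 (0.69 log units; beyond the scatter). For compound 3 the estimated value is 20000 nM, with an expected range from 5000 nM to 80000 nM.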

Compound 3, half-maximal inhibitory concentration: 5300 nM
Estimate against measurement, compound 3: 3.8-fold (0.58 log units) above, within the range that was stated.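

In this assay, the open-chain 3-(diethylamino)propyl side chain of compound 3 gives a measured number where the ring-bearing 2-(piperidin-1-yl)ethyl side chain does not, with an at least 18-fold lower number from compound 2 to compound 3 (1.27 log units; beyond the scatter). Compound 2 sits at a limit of the assay and not at a number, so this step gives only a bound: the limit of > 100000 nM in this assay, at which 1 of the 3 values shown sits. The two open-chain amines read alike, with a 1.7-fold lower number from compound 1 to compound 3 (0.23 log units; within the scatter), so (diethylamino)methyl in place of diisopropylamino shows no difference that can be told from the scatter, and among these three compounds only the piperidine compound stands apart.

The change from compound 2 to compound 3 alters the ring and the chain length at once, so the two cannot be separated here; a 3-(piperidin-1-yl)propyl chain or a 2-(diethylamino)ethyl chain on the same core would pull them apart. Among these compounds, also open is whether the ring itself matters or only this particular ring, which other ring amines, such as morpholine or pyrrolidine, could show in this assay.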